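The source may report more compounds than this note shows. Statements on the series, on what has been measured and on what is new or still open speak of the compounds shown alone.

Compound 1 `CCN(Cc1ccc(F)cc1)c1cccc(C(=O)N2CCc3ccc(OS(N)(=O)=O)cc3C2)c1`: 66.5%
Compound 2 `CCN(Cc1ccccn1)c1cccc(C(=O)N2CCc3ccc(OS(N)(=O)=O)cc3C2)c1`: 19.9%

In an assay on HEK293 cells for inhibition of Steryl-sulfatase (Homo sapiens), tested at 1 uM (a lower number here means a weaker effect, a higher number a stronger effect of the compound at the concentration tested), compound 2 gives 19.9%, the lowest of the two numbers; the step of a number 46.6 percentage points lower from compound 1 to compound 2 (beyond the scatter) is large and beyond the scatter. Compound 3 `CCCN(CCC)c1cccc(C(=O)N2CCc3ccc(OS(N)(=O)=O)cc3C2)c1` differs from compound 2 by dipropylamino in place of ethyl((pyridin-2-yl)methyl)amino on an aromatic carbon. For the measured compounds named here, no measured step matches this change exactly; the step from compound 1 to compound 2 shows only that the group on this amino nitrogen matters strongly in this assay. Removing the pyridin-2-yl ring is therefore expected to move the number, most likely upward, though with wide uncertainty. Compound 3 is estimated at 40%, between 10% and 75%, an expected step of a number 20.1 percentage points higher from compound 2 to compound 3 (beyond the scatter).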

Compound 3, a percentage reported as inhibition, at one concentration (the size of the read-out at that concentration, not a potency): 54.8%
Compound 3: the middle estimate sits 14.8 percentage points below what was measured; the range from low to high includes it.
By their numbers in this assay, from the lowest: compound 2; then compound 3; then compound 1.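

The step of a number 34.9 percentage points higher from compound 2 to compound 3 (beyond the scatter) shows that dipropylamino, an amino group with no ring, can carry much of the inhibition in this assay. The step of a number 11.7 percentage points lower from compound 1 to compound 3 (beyond the scatter) is smaller, so this group falls short of ethyl(4-fluorobenzyl)amino but stays closer to it than ethyl((pyridin-2-yl)methyl)amino does. Nothing measured here explains these differences.
Still open, going by these compounds, is how shorter chains such as diethylamino, or a closed ring such as piperidin-1-yl, would compare. Also open, on these data alone, is whether a plain benzyl group, without fluorine, would match ethyl(4-fluorobenzyl)amino.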